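Isopropoxy in Place of Methoxy: an Expected Rat Dose

The compounds below may be only part of what the source reports. "The series", "measured", "known", "first", "only" and "open" are said of these compounds alone.

In a functional assay on the whole organism (strain Sprague-Dawley) for inhibition, with Rattus norvegicus as the target (on this read-out lower numbers stand for an effect already at smaller amounts and higher numbers for an effect only at larger amounts of compound), compound 2 `COc1cccc2c(=O)c(-c3nn[nH]n3)c[nH]c12` gives 0.312 mg/kg. Compound 1 `O=c1c(-c2nn[nH]n2)c[nH]c2c(Cl)ccc(Cl)c12` gives 0.312 mg/kg in this assay, level with compound 2 at the digits shown and within the scatter. For compound 3 `O=c1c(-c2nn[nH]n2)c[nH]c2ccc(Cl)cc12` this assay reports only a limit, > 25 mg/kg. That the limit of > 25 mg/kg in this assay, at which 1 of the 3 values shown sits, is a limit of the assay and not a number. No two of the measured compounds differ in a single place. Compound 4 `CC(C)Oc1cccc2c(=O)c(-c3nn[nH]n3)c[nH]c12` differs from compound 2 in one place: isopropyl in place of methyl on an oxygen on an aromatic ring. For the measured compounds named here, no measured compound bears on this change, so the step in this assay is expected to stay within the scatter or to be small in either direction. Compound 4 is estimated at 0.5 mg/kg, between 0.15 mg/kg and 3 mg/kg. The expected step is a 1.6-fold higher number from compound 2 to compound 4 (0.20 log units; within the scatter).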

Compound 4, minimum effective dose: 1.25 mg/kg
The estimate for compound 4 lay 2.5-fold (0.40 log units) below the measured number; low and high end bracket the measured number.
By their numbers in this assay, from the lowest: compounds 1 and 2 (each within the scatter of the next); then compound 4. At a limit, above all of these: compound 3.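

In this assay, for the compounds shown here, methoxy to isopropoxy gives a 4.0-fold higher number from compound 2 to compound 4 (0.60 log units; beyond the scatter), the first step between compounds that differ in one place. It shows that the group on this oxygen is not interchangeable on this read-out, although the change is modest. Nothing measured here accounts for the step. From the compounds shown here alone, whether an ethoxy group would read closer to compound 2 or to compound 4 stays open. So does the reading of a hydroxy group, an amine or a longer chain in this place.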